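Swapping the Nitro for a Methylsulfonyl on a Shared Core

This account rests on a few compounds, and the source may have more. Where it says the series, first, only, none or still open, it means among the compounds named here.

Compound 1 `O=C(CCCc1ccc([N+](=O)[O-])cn1)N1CCc2c(Cl)c(O)c(O)c(Cl)c2C1` carries a nitro group on an aromatic carbon of a shared core. In a functional assay (Homo sapiens), tested at 10 uM (a higher number here means a weaker effect of the compound at the concentration tested, a lower number a stronger effect), compound 1 gives 33%. Compound 2 `N#Cc1ccc(CCCC(=O)N2CCc3c(Cl)c(O)c(O)c(Cl)c3C2)nc1` gives 34%, and compound 3 `COc1ccc(CCCC(=O)N2CCc3c(Cl)c(O)c(O)c(Cl)c3C2)nc1` gives 31%. Among these three numbers compound 1 stands second highest, but every gap is small: the step of a number 1 percentage points higher from compound 1 to compound 2 (within the scatter), the step of a number 2 percentage points lower from compound 1 to compound 3 (within the scatter) and the step of a number 3 percentage points lower from compound 2 to compound 3 (within the scatter) all lie within the scatter. Exchanging the nitro for cyano or methoxy on that aromatic carbon has thus left the read-out essentially unchanged.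

Compound 4 `CS(=O)(=O)c1ccc(CCCC(=O)N2CCc3c(Cl)c(O)c(O)c(Cl)c3C2)nc1` has not yet been measured. Compared with compound 1, the change is methylsulfonyl in place of nitro on an aromatic carbon. The steps of a number 1 percentage points higher from compound 1 to compound 2 (within the scatter) and a number 2 percentage points lower from compound 1 to compound 3 (within the scatter) bear directly on this change. Both also replace the nitro of compound 1 by another small group on the same aromatic carbon, and neither moved the read-out beyond the scatter. On that basis the expected step is no change at the digits printed from compound 1 to compound 4 (within the scatter), that is, no change beyond the scatter, in no particular direction. Compound 4 is therefore estimated to give 33% in this assay, with a likely range from 22% to 44%.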

Compound 4, a percentage reported as activity, at one concentration (the size of the read-out at that concentration, not a potency): 72%
Compound 4: middle estimate off by 39 percentage points, on the low side; measured number above the stated range.
By their numbers in this assay, from the lowest: compounds 3, 1 and 2 (each within the scatter of the next); then compound 4.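

In this assay, the aromatic carbon that seemed indifferent to an exchange among nitro, cyano and methoxy proves sensitive to at least one further group: methylsulfonyl gives a number 39 percentage points higher from compound 1 to compound 4 (beyond the scatter), a number 38 percentage points higher from compound 2 to compound 4 (beyond the scatter) and a number 41 percentage points higher from compound 3 to compound 4 (beyond the scatter), which means a clearly weaker effect at the concentration tested. The agreement among the first three compounds therefore did not extend to every group at this position, and the tolerance they suggested holds only for those three groups. The computed tallies do not separate nitro from methylsulfonyl on hydrogen-bond donors, hydrogen-bond acceptors or net charge, and no measurement is available to account for the jump.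

The compounds shown leave open whether the jump belongs to the sulfonyl unit itself or to the methyl attached to it, a question that an ethylsulfonyl group or a plain sulfonamide on the same carbon would help to settle. Also open, as far as these compounds go, is how an amine or a carboxylic acid would read at this position, and whether methylsulfonyl would have the same effect on a different core.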